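The compounds below may be only part of what the source reports. "The series", "measured", "known", "first", "only" and "open" are said of these compounds alone.

Of the compounds shown here, three have been measured so far in an ADME assay on Vero cells (Chlorocebus sabaeus) for cytotoxicity, read by MTT assay, with a stated time of 72 h; on this read-out lower numbers stand for stronger inhibition and higher numbers for weaker inhibition. Compound 1, with the structure `COc1ccc(-c2ccnc(Nc3cccc(C(N)=O)c3)n2)cc1`, gives 2700 nM in this assay. Compound 2, with the structure `COc1ccc(-c2ccnc(Nc3ccc(C(N)=O)cc3)n2)cc1`, gives 5400 nM. Compound 3, with the structure `Cc1csc(-c2ccnc(Nc3ccc(C(N)=O)cc3)n2)c1`, gives 6200 nM. Compound 1 and compound 2 are built from the same atoms joined differently; the difference between the two cores is not broken down here, and what can be said is only what their two values show, which lie within the scatter of each other.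

Compound 2 and compound 3 differ in one place: 4-methylthiophen-2-yl in place of 4-methoxyphenyl on an aromatic carbon. That change gave a 1.1-fold higher number from compound 2 to compound 3 (0.06 log units; within the scatter), so the two numbers are, for practical purposes, indistinguishable.

Compound 4, with the structure `Cc1csc(-c2ccnc(Nc3cccc(C(N)=O)c3)n2)c1`, has not yet been measured. It differs from compound 1 by 4-methylthiophen-2-yl in place of 4-methoxyphenyl on an aromatic carbon. This is the same change that separates compound 2 from compound 3, made at a place described in the same words, and it appears in two pairs among the compounds shown.

Because the earlier step is a 1.1-fold higher number from compound 2 to compound 3 (0.06 log units; within the scatter), the expectation is that compound 4 will sit close to compound 1, with an estimated step of a 1.1-fold higher number from compound 1 to compound 4 (0.05 log units; within the scatter). Compound 4 is therefore estimated at about 3000 nM in this assay, with a likely range from 1500 nM to 6500 nM.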

Compound 4, half-maximal inhibitory concentration: > 100000 nM
Compound 4 was reported as a limit (the forecaster's own chance of this, stated with the estimate: 5%); middle value at least 33-fold (1.52 log units) from the limit.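

In this assay, compound 4 gives > 100000 nM, which is a limit of the assay and not a number: the limit of > 100000 nM in this assay, at which 1 of the 4 values shown sits. Putting 4-methylthiophen-2-yl in place of 4-methoxyphenyl gave an at least 37-fold higher number from compound 1 to compound 4 (1.56 log units; beyond the scatter), so the step seen on one core did not carry over to the other, and the two results differ clearly: the same change on two cores in this assay, a 1.1-fold higher number (0.06 log units; within the scatter) from compound 2 to compound 3 and an at least 37-fold higher number (1.56 log units; beyond the scatter) from compound 1 to compound 4, at least 32-fold (1.50 log units) apart, beyond the scatter of two such steps. This shows that, in these two pairs, the outcome of the change depends on the core that carries it, but with one pair per core it gives no general rule for the series, does not show which difference between the cores matters, and, with one end of the step resting on a limit, does not give the full size of the step.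

The compounds shown leave open whether the same large step would appear on the core of compound 1 with a different group in that place, such as a plain phenyl or a thiophen-2-yl without the methyl. They also leave open how either core would behave if its primary amide were replaced by a carboxylic acid or a nitrile.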